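Removing a Methyl from a Fused Aromatic Core

The compounds below may be only part of what the source reports. "The series", "measured", "known", "first", "only" and "open" are said of these compounds alone.

Compound 1 `CCCCCCCCc1nc2ccc(C)cc2nc1CCCCCCCC(=O)O` is one of two compounds tested in a functional assay on the whole organism for inhibition, with Rattus norvegicus as the target, read by paw edema, with a stated time of 3 h, at a dose of 100 mg/kg by the oral route; a higher number here means more inhibition at the dose given (going by the name of the read-out), a lower number less inhibition. In this assay compound 1 gives 12.5%, the higher of the two numbers. Compound 2 `CCCCCCCCC1=NC(=O)N=C1CCCCCCCC(=O)O` gives -12.9%, a number that lies beyond the usual scatter below compound 1. Compound 3 `CCCCCCCCc1nc2ccccc2nc1CCCCCCCC(=O)O` differs from compound 1 in a single place: hydrogen in place of methyl on an aromatic carbon. For the measured compounds named here, no measured pair shows a change of this kind, so the step is expected to be small, most likely within the scatter, with a slight lean downward. Compound 3 is expected to give 8%, with a range from -12% to 28%. The expected step is a number 4.5 percentage points lower from compound 1 to compound 3 (within the scatter).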

Compound 3, a percentage reported as inhibition, in the whole organism at one dose (the size of the read-out at that dose, not a potency): 34.4%
Estimate against measurement, compound 3: 26.4 percentage points below; the whole stated range lies below it.
By their numbers in this assay, from the lowest: compound 2; then compound 1; then compound 3.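

In this assay, removing the methyl from this aromatic carbon is not a neutral change: the step is a number 21.9 percentage points higher from compound 1 to compound 3 (beyond the scatter). The position therefore matters to the read-out, and the methyl of compound 1 is not needed for inhibition at this dose. Nothing at hand gives a reason for this step.

From the compounds shown here alone, it remains open whether a different group at this place, such as a chlorine atom, a methoxy group or an amine, would match hydrogen or methyl. A single pair also cannot show whether this change would act the same way on another core.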